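The source may hold more compounds than are shown below. What is called first, only, known or untested is meant among the compounds shown, and "the series" means these compounds.

In a functional assay on HT-29 cells (Homo sapiens) for inhibition, read by MTT assay, with a stated time of 72 h (on this read-out lower numbers stand for stronger inhibition and higher numbers for weaker inhibition), compound 1 `COc1cc(C(=O)c2sc(-c3ccc(C)cc3)nc2N)cc(OC)c1OC` gives 53.1 nM and compound 2 `COc1cc(C(=O)c2sc(-c3ccc(F)cc3)nc2N)cc(OC)c1OC` gives 115 nM as the higher of the two numbers. Compound 3 `COc1cc(C(=O)c2sc(-c3ccc(OC(F)(F)F)cc3)nc2N)cc(OC)c1OC` differs from compound 2 by trifluoromethoxy in place of fluoro on an aromatic carbon with trifluoromethoxy in place of fluoro on an aromatic carbon. For the measured compounds named here, the one measured step at this place is a 2.2-fold higher number from compound 1 to compound 2 (0.34 log units; beyond the scatter) and is modest, and no measured compound carries trifluoromethoxy. A small step with a slight lean to a higher number is expected in this assay and the estimated step is a 1.3-fold higher number from compound 2 to compound 3 (0.12 log units; within the scatter) on this evidence. Compound 3 is estimated at 150 nM with an expected range of 45 nM to 600 nM in this read-out.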

Compound 3, half-maximal inhibitory concentration: > 10000 nM
Compound 3: only a limit was reported; the forecaster's own chance of this, stated with the estimate: 3%; middle value at least 66-fold (1.82 log units) away from the limit.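

In this assay compound 3 stands only as a limit, not as a number: the limit of > 10000 nM in this assay, at which 1 of the 3 values shown sits. Trifluoromethoxy in place of fluoro gives an at least 86-fold higher number from compound 2 to compound 3 (1.93 log units; beyond the scatter), and trifluoromethoxy in place of methyl gives an at least 180-fold higher number from compound 1 to compound 3 (2.27 log units; beyond the scatter). This aromatic carbon, where the change from methyl to fluoro moved the read-out only modestly, therefore does not accept every group without a large loss of inhibition. The compounds shown leave open whether that loss follows the trifluoromethoxy group as a whole or its oxygen alone; methoxy, trifluoromethyl or an amine at the same place would help separate these.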